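A few compounds are considered here, and "the series" means these few. Any claim that something is new, unique, unknown or untested is made for them only; others in the source may bear on it.

Among the compounds with values here, in a functional assay on HeLa cells (Homo sapiens) for antiproliferative activity, read by MTT assay, with a stated time of 24 h (on this read-out lower numbers stand for stronger inhibition and higher numbers for weaker inhibition), compound 2 (`Cc1ccc(CSc2nnc(-c3ccc4c(c3)OCCO4)n2-c2ccccc2)cc1`) gives 49700 nM and compound 1 (`Cc1ccccc1CSc1nnc(-c2ccc3c(c2)OCCO3)n1-c1ccccc1`) gives 36000 nM, so compound 2 stands level with its only neighbour. Within the data shown here, the single measured step is a 1.4-fold higher number from compound 1 to compound 2 (0.14 log units; within the scatter) and lies within the scatter. Compound 3 (`Fc1ccccc1CSc1nnc(-c2ccc3c(c2)OCCO3)n1-c1ccccc1`) brings 2-fluorophenyl in place of 4-methylphenyl on a saturated chain carbon bound to a sulfur in the form of 2-fluorophenyl in place of 4-methylphenyl on a saturated chain carbon bound to a sulfur. Among the measured compounds shown here, the measured step only exchanges 2-methylphenyl and 4-methylphenyl, and no fluorinated compound has been measured, so no step beyond the scatter is expected in this assay here. An estimated 1.2-fold lower number from compound 2 to compound 3 (0.09 log units; within the scatter) is all that is expected. Compound 3 is expected at 40000 nM with an estimated range of 18000 nM to 90000 nM for now.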

Compound 3, half-maximal inhibitory concentration: 24300 nM
Beside the measured number, compound 3's estimate is 1.6-fold (0.22 log units) above it; the measured number falls inside the stated range.
By their numbers in this assay, from the lowest: compounds 3, 1 and 2 (each within the scatter of the next, the first and the last beyond it).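

In this assay, a change on a saturated chain carbon bound to a sulfur now gives a step beyond the scatter, though a modest one (a 2.0-fold lower number from compound 2 to compound 3 (0.31 log units; beyond the scatter)). Fluoro in place of methyl on an aromatic carbon stays within the scatter (a 1.5-fold lower number from compound 1 to compound 3 (0.17 log units; within the scatter)), so 2-fluorophenyl and 2-methylphenyl read as level here. No evidence bearing on the cause of either step is available.

Still open, from the compounds shown here alone, is whether an amine or a carboxylic acid on this phenyl ring would move the number further than these steps. The same applies to a longer chain in place of 2-fluorobenzyl.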